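The source may report more compounds than this note shows. Statements on the series, on what has been measured and on what is new or still open speak of the compounds shown alone.

Going by the values given here, in a functional assay on NCI-H460 cells (Homo sapiens) for antiproliferative activity, read by XTT assay, with a stated time of 72 h (a lower number here means a stronger inhibitor, a higher number a weaker inhibitor), compound 2 `COc1ccc(-c2cc3ccccc3nc2/C=C/C(=O)c2ccc(F)cc2)cc1` gives 6990 nM as the only actual number among the three compounds tested so far. Compound 1 `COc1ccc(-c2cc3ccccc3nc2C=O)cc1` shows > 10000 nM as its result, and this is a limit of the assay, not a number. Compound 3 `COc1ccc(C(=O)/C=C/c2nc3ccccc3cc2-c2ccc(OC)cc2)cc1` shows > 10000 nM as its result, and this too is a limit. With the limit of > 10000 nM in this assay, at which 2 of the 3 values shown sit, as the picture, compound 2 has no numeric neighbour to be ranked against.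

Compound 4 `COc1ccc(-c2cc3ccccc3nc2/C=C/C(=O)c2ccc(OC)c(OC)c2)cc1` has not yet been measured. The change 3,4-dimethoxyphenyl in place of 4-fluorophenyl on a carbonyl carbon puts 3,4-dimethoxyphenyl in place of 4-fluorophenyl on a carbonyl carbon, and the rest of compound 2 stays as it is. Among the compounds with values here, the one measured step that bears on this is an at least 1.4-fold higher number from compound 2 to compound 3 (0.15 log units; that floor lies within the scatter) with methoxy in place of fluoro on an aromatic carbon, and its size is known only as a floor. Resting on an at least 1.4-fold higher number from compound 2 to compound 3 (0.15 log units; that floor lies within the scatter) as the sole guide, a small step toward a higher number is expected in this assay and it may well stay within the scatter. The expected change is a 1.3-fold higher number from compound 2 to compound 4 (0.11 log units; within the scatter) on this estimate. For compound 4 the estimated value is 9000 nM with an expected range from 3000 nM to 25000 nM as its outer ends.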

Compound 4, half-maximal inhibitory concentration: 7540 nM
The estimate for compound 4 lay 1.2-fold (0.08 log units) above the measured number, within the range that was stated.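

Putting 3,4-dimethoxyphenyl in place of 4-fluorophenyl on a carbonyl carbon gives a 1.1-fold higher number from compound 2 to compound 4 (0.03 log units; within the scatter) in this assay, so a group with more heavy atoms and with hydrogen-bond acceptors is taken up on this carbon without a shift that can be told from the scatter. Compound 3 gives > 10000 nM, and this is a limit of the assay, not a number. Methoxy in place of hydrogen on an aromatic carbon gives an at least 1.3-fold lower number from compound 3 to compound 4 (0.12 log units; that floor lies within the scatter), and this size can be read only as a floor because compound 3 rests on a limit: the limit of > 10000 nM in this assay, at which 2 of the 4 values shown sit.

From the compounds shown here alone, it remains open whether an amine or a carboxylic acid in place of these aromatic groups on the carbonyl carbon would move the number beyond the scatter in this assay or leave it where compound 2 and compound 4 stand. Equally open, going by these compounds, is how a longer chain carrying the carbonyl would read, with the rest of compound 2 kept as it is.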